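Swapping a fluoropyridine for a methoxyphenyl on the tetrazole

The compounds below may be only part of what the source reports. "The series", "measured", "known", "first", "only" and "open" are said of these compounds alone.

Measured so far in an assay on HEK293 cells for activation of Kir3.1/Kir3.2 (Homo sapiens), read by thallium flux; a higher number here means that more compound is needed for the effect, a lower number that less compound is needed:
compound 1, `Cc1cc(NC(=O)Cn2nnc(-c3ccc(Cl)c(Cl)c3)n2)n(C2CCCCC2)n1`: 1220 nM
compound 2, `Cc1cc(NC(=O)Cn2nnc(-c3ccnc(F)c3)n2)n(C2CCCCC2)n1`: 441 nM
compound 3, `Cc1cc(NC(=O)Cn2nnc(-c3cccc(F)n3)n2)n(C2CCCCC2)n1`: > 3000 nM

Compound 3 reaches only a limit of this assay, (the limit of > 3000 nM in this assay, at which 1 of the 3 values shown sits), so no number is known for it. It nonetheless stands weakest of the three: the step of an at least 2.4-fold higher number from compound 1 to compound 3 (0.39 log units; beyond the scatter) and the step of an at least 6.8-fold higher number from compound 2 to compound 3 (0.83 log units; beyond the scatter) both go beyond the scatter, and both point the same way, with compound 3 at the unfavourable end.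

Compound 4, `COc1ccc(-c2nnn(CC(=O)Nc3cc(C)nn3C3CCCCC3)n2)cc1`, differs from compound 3 in one place: 4-methoxyphenyl in place of 6-fluoropyridin-2-yl on an aromatic carbon. Among the compounds with values here, the one measured step that bears on the same place is the step from compound 1, which carries a carbon-only ring, to compound 3, which carries a ring with one nitrogen: an at least 2.4-fold higher number from compound 1 to compound 3 (0.39 log units; beyond the scatter). Going back from the fluoropyridine to a carbon-only ring may therefore recover part of that loss, and in this assay a step of about an at least 2.5-fold lower number from compound 3 to compound 4 (0.39 log units; beyond the scatter) is expected. Compound 4 is thus estimated at 1200 nM, within a range from 400 nM to 3000 nM.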

Compound 4, half-maximal effective concentration: 175 nM
For compound 4 the middle estimate is 6.9-fold (0.84 log units) above the measured one; the whole stated range lies above it.
By their numbers in this assay, from the lowest: compound 4; then compound 2; then compound 1. At a limit, above all of these: compound 3.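

Compound 3 remains a limit in this assay, not a number: the limit of > 3000 nM in this assay, at which 1 of the 4 values shown sits. Even against that limit, the change at this position is large (an at least 17-fold lower number from compound 3 to compound 4 (1.23 log units; beyond the scatter)), so the nature of the group on this aromatic carbon can strongly shift the amount of compound needed. A carbon-only ring alone does not explain the result: the 4-methoxyphenyl also gives a lower number than the 3,4-dichlorophenyl (a 7.0-fold lower number from compound 1 to compound 4 (0.84 log units; beyond the scatter)) and the 2-fluoropyridin-4-yl (a 2.5-fold lower number from compound 2 to compound 4 (0.40 log units; beyond the scatter)), while compound 1 goes against any preference for carbon-only rings (a 2.8-fold lower number from compound 1 to compound 2 (0.44 log units; beyond the scatter)).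

Going by these compounds, it remains open whether the methoxy group itself matters, which a 4-methylphenyl or 4-hydroxyphenyl would help to test. A 3-methoxyphenyl would show whether the place of that group on the ring matters.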